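Swapping the Ketone Aryl Group on a Benzoxaborole Chalcone

A few compounds are considered here, and "the series" means these few. Any claim that something is new, unique, unknown or untested is made for them only; others in the source may bear on it.

Of the compounds shown here, three sharing one core have been tested in a functional assay on HCT-116 cells (Homo sapiens) for cytotoxicity, read by MTT assay, with a stated time of 48 h; a lower number here means a stronger inhibitor, a higher number a weaker inhibitor. Compound 1 `O=C(/C=C/c1ccc2c(c1)B(O)OC2)c1ccc(-c2ccccc2)cc1` carries a biphenyl group on the carbonyl carbon; in this assay compound 1 gives 9500 nM. Compound 2 `O=C(/C=C/c1ccc2c(c1)B(O)OC2)c1cccs1` carries a thiophen-2-yl group there, and compound 2 gives 14200 nM. Compound 3 `Cn1cccc1C(=O)/C=C/c1ccc2c(c1)B(O)OC2` carries a 1-methyl-1H-pyrrol-2-yl group, and for compound 3 the assay reports only a limit, > 100000 nM, not a number. Compound 3 therefore stands at the weak end of what has been measured. The change from thiophen-2-yl to the pyrrole gave an at least 7.0-fold higher number from compound 2 to compound 3 (0.84 log units; beyond the scatter), a step known only as a lower bound since the limit of > 100000 nM in this assay, at which 1 of the 3 values shown sits, is where compound 3 sits.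

Compound 4 `O=C(/C=C/c1ccc2c(c1)B(O)OC2)c1ccc(Cl)cc1` now replaces that pyrrole with a 4-chlorophenyl group: 4-chlorophenyl in place of 1-methyl-1H-pyrrol-2-yl on a carbonyl carbon. Within the data shown here, no measured step covers a chlorophenyl directly, but both aryl ketones of this series, compound 1 and compound 2, sit in the same region. Compound 4 is expected to give a measurable number, because compound 1 gives 9500 nM with a plain phenyl-type ring. The expected step is an at least 8.3-fold lower number from compound 3 to compound 4 (0.92 log units; beyond the scatter). Compound 4 is therefore expected to give 12000 nM, within 4000 nM to 50000 nM.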

Compound 4, half-maximal inhibitory concentration: 9300 nM
The estimate for compound 4 lay 1.3-fold (0.11 log units) above the measured number; the measured number falls inside the stated range.
By their numbers in this assay, from the lowest: compounds 4, 1 and 2 (each within the scatter of the next). At a limit, above all of these: compound 3.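

From the compounds shown here alone, putting 4-chlorophenyl on the carbonyl carbon in place of 1-methyl-1H-pyrrol-2-yl gave an at least 10-fold lower number from compound 3 to compound 4 (1.03 log units; beyond the scatter) in this assay, so a single swap at this position is enough to return a measurable number, and the true size of the step stays unknown because compound 3 sits at a limit: the limit of > 100000 nM in this assay, at which 1 of the 4 values shown sits. Compound 4 cannot be told apart from the other two compounds, since 4-chlorophenyl in place of thiophen-2-yl gave a 1.5-fold lower number from compound 2 to compound 4 (0.18 log units; within the scatter) and chloro in place of phenyl on an aromatic carbon gave a 1.0-fold lower number from compound 1 to compound 4 (0.01 log units; within the scatter). Among these compounds, the chloro of compound 4 and the phenyl of compound 1 therefore read alike on this ring, which the earlier compounds could not show, and of the four compounds only compound 3 stands apart.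

Still open, going by these compounds, is whether a ring carrying an amine or a carboxylic acid in place of the chloro would stay with compound 1, compound 2 and compound 4 or fall toward compound 3. Also open, on these data alone, is what sets compound 3 apart, the pyrrole ring itself or its methyl, a question that a pyrrol-2-yl group without that methyl would help to answer.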